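The source may report more compounds than this note shows. Statements on the series, on what has been measured and on what is new or still open speak of the compounds shown alone.

Of the compounds shown here, three have been measured in a functional assay on HCT-116 cells (Homo sapiens) for antiproliferative activity, read by MTT assay, with a stated time of 72 h; on this read-out higher numbers stand for weaker inhibition and lower numbers for stronger inhibition. Compound 1 `COc1ncc(-c2ccc3c(c2)N(c2ccccc2)C(=O)CO3)cc1NS(=O)(=O)c1ccc(F)cc1` gives 18800 nM, and compound 2 `COc1ncc(-c2ccc3c(c2)N(c2ccc(Cl)cc2)C(=O)CO3)cc1NS(=O)(=O)c1ccc(F)cc1`, which carries a chloro group in place of one hydrogen on the phenyl ring attached to the core nitrogen, gives 19200 nM. The change from compound 2 to compound 1, (hydrogen in place of chloro on an aromatic carbon), produced a 1.0-fold lower number from compound 2 to compound 1 (0.01 log units; within the scatter), so within this pair the chloro group made no measurable difference in this assay.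

Compound 3 `O=C1COc2ccc(-c3cnc4ccccc4c3)cc2N1c1ccc(Cl)cc1` is built on a different core; how that core differs from the core of compound 2 is not broken down here. In this assay compound 3 gives 36100 nM, which stands within the scatter of both compound 1 and compound 2.

Compound 4 `O=C1COc2ccc(-c3cnc4ccccc4c3)cc2N1c1ccccc1` has not yet been measured. It differs from compound 3 by hydrogen in place of chloro on an aromatic carbon, the same change, at the same kind of place, that separates compound 2 from compound 1. Resting on the step of a 1.0-fold lower number from compound 2 to compound 1 (0.01 log units; within the scatter), the step from compound 3 to compound 4 is expected to be about a 1.0-fold lower number from compound 3 to compound 4 (0.00 log units; within the scatter). Compound 4 is therefore estimated at 36000 nM, with a likely range from 18000 nM to 72000 nM.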

Compound 4, half-maximal inhibitory concentration: > 40000 nM
Compound 4: no number, only a limit (the forecaster's own chance of this, stated with the estimate: 15%); middle value at least 1.1-fold (0.04 log units) away from the limit.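

For compound 4 the assay gives only a limit, not a number: the limit of > 40000 nM in this assay, at which 1 of the 4 values shown sits. Read from that limit, replacing the chloro of the 4-chlorophenyl group with hydrogen gives an at least 1.1-fold higher number from compound 3 to compound 4 (0.04 log units; that floor lies within the scatter), and set beside the same change on the other core in this assay, the picture is this: the same change on two cores in this assay, a 1.0-fold lower number (0.01 log units; within the scatter) from compound 2 to compound 1 and an at least 1.1-fold higher number (0.04 log units; that floor lies within the scatter) from compound 3 to compound 4; the limit leaves it open whether they differ. Going by these compounds, the pair of steps therefore gives no sign that the change matters more on one core than on the other, but it does not show that the change carries over unchanged, since the true size of the second step is unknown and a larger step on the core of compound 3 cannot be ruled out.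

The compounds shown leave open whether other groups at the same place on that ring, such as a methoxy group, an amine or a carboxylic acid, would shift the number on either core. Also open, on these data alone, is how this change would read on a core whose compounds both give numbers well clear of the limit, so that the step could be measured at both ends.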